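Working notes: the step from compound 3 to compound 4

The source may hold more compounds than are shown below. What is called first, only, known or untested is meant among the compounds shown, and "the series" means these compounds.

Within the data shown here, in a functional assay on NCI-H460 cells (Homo sapiens) for inhibition, read by MTT assay, with a stated time of 72 h (on this read-out lower numbers stand for stronger inhibition and higher numbers for weaker inhibition), compound 3 (`COc1cc(NC(C)CCCNC(=O)NNC(=O)Nc2cccc(F)c2)c2ncccc2c1`) gives 50000 nM, the highest of the two actual numbers so far. Compound 1 (`COc1cc(NC(C)CCCNC(=O)Nc2cccc(F)c2)c2ncccc2c1`) gives 24000 nM. Compound 2 (`COc1cc(NC(C)CCCNC(=O)NNC(=O)Nc2ccc(F)cc2)c2ncccc2c1`) gives > 100000 nM, which is a limit of the assay and not a number.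

Compound 4 (`COc1cc(NC(C)CCCNC(=O)Nc2cccc(C(F)(F)F)c2)c2ncccc2c1`) has 3-(trifluoromethyl)phenyl in place of ((3-fluorophenyl)carbamoyl)amino on an amide-type nitrogen.

The closest measured change is a 2.1-fold higher number from compound 1 to compound 3 (0.32 log units; beyond the scatter), which introduces ((3-fluorophenyl)carbamoyl)amino in place of 3-fluorophenyl. Leaving that group should therefore reverse this change. The change an at least 4.1-fold higher number from compound 1 to compound 2 (0.61 log units; beyond the scatter) points the same way, while an at least 2.0-fold lower number from compound 2 to compound 3 (0.30 log units; that floor lies within the scatter) gives only a floor within the scatter. Among the measured compounds shown here, no measured step covers 3-(trifluoromethyl)phenyl in place of 3-fluorophenyl, so that part of the change remains open and widens the range.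

A modest move to a lower number is expected, similar in size to the reverse of the step from compound 1 to compound 3. The estimated change is a 2.3-fold lower number from compound 3 to compound 4 (0.36 log units; beyond the scatter). Compound 4 is expected at 22000 nM, with an estimated range from 8000 nM to 60000 nM.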

Compound 4, half-maximal inhibitory concentration: 21000 nM
Compound 4: the middle estimate sits 1.0-fold (0.02 log units) above what was measured; the measured number falls inside the stated range.
By their numbers in this assay, from the lowest: compounds 4 and 1 (each within the scatter of the next); then compound 3. At a limit, above all of these: compound 2.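

In this assay, among these compounds, a 1.1-fold lower number from compound 1 to compound 4 (0.06 log units; within the scatter), so trifluoromethyl in place of fluoro on an aromatic carbon gives no readable change, a swap that the earlier compounds did not cover. With that swap flat, the data show a 2.4-fold lower number from compound 3 to compound 4 (0.38 log units; beyond the scatter). The earlier step from compound 1 to compound 3 can be read alongside it: on an amide-type nitrogen whose other neighbour is the carbonyl carbon, the lower number goes with the loss of ((3-fluorophenyl)carbamoyl)amino, while the aromatic substituent adds nothing that can be read. Against the 4-fluorophenyl member of the longer series, an at least 4.7-fold lower number from compound 2 to compound 4 (0.67 log units; beyond the scatter), which gives only a floor and agrees with that reading.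

Compound 2 stands at a limit of the assay and not at a number: the limit of > 100000 nM in this assay, at which 1 of the 4 values shown sits.

Only fluoro and trifluoromethyl are shown on this phenyl ring, so it remains open whether a nitrile, a methoxy or a chloro there would move the number away from the level shared by compound 1 and compound 4. On these data alone, it is equally open whether a cyclohexyl in place of the phenyl ring on that nitrogen would keep this level.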